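The source may hold more compounds than are shown below. What is called first, only, known or untested is meant among the compounds shown, and "the series" means these compounds.

Working notes on the series. Compound 3 `CN(Cc1ccc(OCCCN)cc1)c1nc2ccc(Oc3cccc(C(F)(F)F)c3)cc2s1` gives 239000 nM in an assay on cells for inhibition of Voltage-dependent T-type calcium channel subunit alpha-1H (Homo sapiens), read by FLIPR and calcium flux, with stated times of 600 s and 300 s (on this read-out higher numbers stand for weaker inhibition and lower numbers for stronger inhibition), the second highest of the three numbers recorded. Its nearest neighbour is compound 1 `NCCCOc1ccc(CNc2nc3ccc(Oc4ccc(O)cc4)cc3s2)cc1`, which gives 300000 nM in this assay, a gap that lies within the scatter; compound 2 `NCCCOc1ccc(CNc2nc3ccc(Oc4ccc(C(F)(F)F)cc4)cc3s2)cc1`, which gives 112000 nM in this assay, sits furthest away, a gap beyond the scatter.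

Compound 4 `NCCCOc1ccc(CNc2nc3ccc(Oc4cccc(C(F)(F)F)c4)cc3s2)cc1` differs from compound 3 in one place: hydrogen in place of methyl on a nitrogen on an aromatic ring. Among the measured pairs the only single-point step is a 2.7-fold lower number from compound 1 to compound 2 (0.43 log units; beyond the scatter), which concerns the group on the phenoxy ring, not the nitrogen on the aromatic ring, so no measured step bears directly on the change from compound 3 to compound 4. What is available is that compound 2 and compound 4 both carry hydrogen on that nitrogen and a trifluoromethyl on the phenoxy ring, and compound 2 gives the lowest number of the three.

The step from compound 3 to compound 4 is therefore expected to be small, a 1.5-fold lower number from compound 3 to compound 4 (0.17 log units; within the scatter), leaning towards the number of compound 2 but not confidently beyond the scatter. Compound 4 is estimated at 160000 nM in this assay, with a range from 60000 nM to 400000 nM.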

Compound 4, half-maximal inhibitory concentration: 171000 nM
For compound 4 the middle estimate is 1.1-fold (0.03 log units) below the measured one; the range from low to high includes it.
By their numbers in this assay, from the lowest: compounds 2, 4, 3 and 1 (each within the scatter of the next, the first and the last beyond it).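

Hydrogen in place of methyl on a nitrogen on an aromatic ring gives a 1.4-fold lower number from compound 3 to compound 4 (0.15 log units; within the scatter) in this assay, so this read-out does not tell the two groups apart at this place, and the earlier compounds offered no step at this nitrogen. The phenoxy group adds a less clear picture: 3-(trifluoromethyl)phenyl in place of 4-(trifluoromethyl)phenyl on an oxygen on an aromatic ring gives a 1.5-fold higher number from compound 2 to compound 4 (0.18 log units; within the scatter), and 3-(trifluoromethyl)phenyl in place of 4-hydroxyphenyl at that place gives a 1.8-fold lower number from compound 1 to compound 4 (0.24 log units; within the scatter), so compound 4 lies within the scatter of both compounds even though a 2.7-fold lower number from compound 1 to compound 2 (0.43 log units; beyond the scatter) separates them. No measurement is available that would explain any of these steps.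

It remains open whether an ethyl group, an acetyl group or a longer chain on this nitrogen would give a step beyond the scatter, since hydrogen and methyl are the only two groups shown there. From the compounds shown here alone, it is also open whether a nitrile or a chlorine on the phenoxy ring would separate from trifluoromethyl in this assay.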